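The source may hold more compounds than are shown below. What is called first, only, known or untested is meant among the compounds shown, and "the series" means these compounds.

Working notes on the series in a functional assay on the whole organism (strain albino) for inhibition, with Rattus norvegicus as the target, read by paw edema, with stated times of 30 min and 2 h, at a dose of 100 mg/kg by the oral route; on this read-out lower numbers stand for less inhibition and higher numbers for more inhibition at the one dose given (going by the name of the read-out).

Compound 1 `COc1ccc(/C=C/C(=O)c2ccc(NC(=O)CBr)cc2)cc1` gives 42%. Among the measured compounds shown here, compound 2 `COc1ccc(/C=C/C(=O)c2ccc(NC(=O)CO[N+](=O)[O-])cc2)cc1` gives 49%; the single measured step, a number 7 percentage points higher from compound 1 to compound 2 (within the scatter), concerns the chain end of the amide and not the aryl ring. Compound 3 `CC(=O)c1ccc(OCC(=O)Nc2ccc(C(=O)/C=C/c3ccc(Cl)cc3)cc2)cc1` gives 52%, the highest of the three numbers, though the gap to compound 2 and the gap to compound 1 are both within the scatter, so no order among the three can be read from these values.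

Compound 4 `COc1ccc(/C=C/C(=O)c2ccc(NC(=O)COc3ccc(C(C)=O)cc3)cc2)cc1` differs from compound 3 as follows: methoxy in place of chloro on an aromatic carbon. For the measured compounds named here, no measured step touches this change; the methoxyphenyl of compound 1 and compound 2 is paired with a different amide chain, and the values of compound 1, compound 2 and compound 3 all lie within the scatter of one another. The step of a number 2 percentage points lower from compound 3 to compound 4 (within the scatter) is therefore expected to be none beyond the scatter. Compound 4 is estimated at 50%, with a range from 38% to 62%.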

Compound 4, a percentage reported as inhibition, in the whole organism at one dose (the size of the read-out at that dose, not a potency): 35%
Compound 4: the middle estimate sits 15 percentage points above what was measured; measured number below the stated range.
By their numbers in this assay, from the lowest: compounds 4, 1, 2 and 3 (each within the scatter of the next, the first and the last beyond it).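

Among the compounds shown here, on the 4-acetylphenoxy amide chain, the aromatic carbon para to a large group is sensitive to its substituent: methoxy in place of chloro gives a number 17 percentage points lower from compound 3 to compound 4 (beyond the scatter) and is the first single change to exceed the scatter. With the 4-methoxyphenyl held constant, the chain end gives a mixed picture, with 4-acetylphenyl in place of nitro on the oxygen giving a number 14 percentage points lower from compound 2 to compound 4 (beyond the scatter) while 4-acetylphenoxy in place of bromo gives a number 7 percentage points lower from compound 1 to compound 4 (within the scatter) and stays within the scatter. No measurement at hand accounts for either step.

Open is whether the methoxy-for-chloro step carries over to the bromo and nitrooxy chain ends, for which the compounds shown hold only the 4-methoxyphenyl form. Also open, as far as these compounds go, is how an amine or a hydroxy group on the same aromatic carbon would compare with chloro and methoxy.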